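Swapping the Aryl Group on a Triazole Nitrogen

A few compounds are considered here, and "the series" means these few. Any claim that something is new, unique, unknown or untested is made for them only; others in the source may bear on it.

Compound 1 `Cc1ccccc1-n1nncc1CN1C(=O)C2(C(C#N)=C(N)Oc3c2c2nc4ccccc4nc2c2ccccc32)c2ccccc21`: > 50000 nM
Compound 2 `N#CC1=C(N)Oc2c(c3nc4ccccc4nc3c3ccccc23)C12C(=O)N(Cc1cnnn1-c1ccc(Cl)cc1)c1ccccc12`: > 50000 nM
Compound 3 `N#CC1=C(N)Oc2c(c3nc4ccccc4nc3c3ccccc23)C12C(=O)N(Cc1cnnn1-c1cccc(Br)c1)c1ccccc12`: > 50000 nM

The value of compound 1 in a functional assay on HCT-116 cells (Homo sapiens) for antiproliferative activity, read by MTT assay, with a stated time of 48 h (a higher number here means a weaker inhibitor, a lower number a stronger inhibitor), is a limit of the assay, not a measured number. The value of compound 2 is likewise a limit. So is that of compound 3, which means (the limit of > 50000 nM in this assay, at which 3 of the 3 values shown sit). Compound 4 `N#CC1=C(N)Oc2c(c3nc4ccccc4nc3c3ccccc23)C12C(=O)N(Cc1cnnn1-c1ccc(N)cc1)c1ccccc12` differs from compound 1 in this way: 4-aminophenyl in place of 2-methylphenyl on an aromatic nitrogen. The steps that alter the same place, a step that the two limits leave unreadable from compound 1 to compound 2 and a step that the two limits leave unreadable from compound 1 to compound 3, cannot be read in size, since both of their ends are limits. They offer no direction, and nothing among these compounds shows that an aminophenyl would change the picture. Compound 4 is therefore expected to give a limit as well, estimated at 60000 nM with a range from 20000 nM to 200000 nM. The expected step is a step that the limit leaves unreadable from compound 1 to compound 4.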

Compound 4, half-maximal inhibitory concentration: 45200 nM
For compound 4 the middle estimate is 1.3-fold (0.12 log units) above the measured one; the measured number falls inside the stated range.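

In this assay, among these compounds, compound 4 is the first with a measured number, which gives the aryl group on the triazole nitrogen steps with a readable direction: an at least 1.1-fold lower number from compound 1 to compound 4 (0.04 log units; that floor lies within the scatter), an at least 1.1-fold lower number from compound 3 to compound 4 (0.04 log units; that floor lies within the scatter) and an at least 1.1-fold lower number from compound 2 to compound 4 (0.04 log units; that floor lies within the scatter). Among the compounds shown here, each floor is small, so the 4-aminophenyl group shows only that this change can leave the limit, not how large the true step is. The other compounds remain at a limit: the limit of > 50000 nM in this assay, at which 3 of the 4 values shown sit.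

From the compounds shown here alone, whether a hydroxyl, a carboxylic acid or a dimethylamino group on that phenyl ring would give a lower number stays open. Going by these compounds, the true size of the steps also stays open, since the values of compound 1, compound 2 and compound 3 are limits.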